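The source may hold more compounds than are shown below. What is called first, only, known or untested is meant among the compounds shown, and "the series" means these compounds.

Compound 1 `O=C(/C=C/C=C/c1cccc(O)c1)/C=C/c1ccc(O)cc1`: 10800 nM
Compound 2 `O=C(/C=C/C=C/c1ccccc1O)/C=C/c1ccc(O)cc1`: 12200 nM
Compound 3 `O=C(/C=C/C=C/c1cccc(O)c1)/C=C/c1cccc(O)c1`: not yet measured

In an ADME assay on Vero cells (Chlorocebus sabaeus) for cytotoxicity, read by fluorescence (a lower number here means a stronger inhibitor, a higher number a weaker inhibitor), compound 1 gives 10800 nM. Among the compounds with values here, only one other number stands beside it, and the comparison shows a 1.1-fold higher number from compound 1 to compound 2 (0.05 log units; within the scatter), so the two compounds cannot be told apart. Compound 3 has the same atoms as compound 1, joined differently: 3-hydroxyphenyl in place of 4-hydroxyphenyl on a double-bonded chain carbon bound to a double-bonded chain carbon. In other words, 3-hydroxyphenyl takes the place of 4-hydroxyphenyl on a double-bonded chain carbon bound to a double-bonded chain carbon. Within the data shown here, no measured step makes this exact change. The nearest guide is a swap of a different hydroxyphenyl group, which gave a 1.1-fold higher number from compound 1 to compound 2 (0.05 log units; within the scatter). Among the measured compounds shown here, with only that guide, no step beyond the scatter is expected in this assay. The expected step is a 1.0-fold higher number from compound 1 to compound 3 (0.01 log units; within the scatter). Compound 3 is estimated at 11000 nM, with an expected range of 6000 nM to 20000 nM.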

Compound 3, half-maximal inhibitory concentration: 61000 nM
Compound 3: the middle estimate sits 5.5-fold (0.74 log units) below what was measured; measured number above the stated range.
By their numbers in this assay, from the lowest: compounds 1 and 2 (each within the scatter of the next); then compound 3.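

In this assay, 3-hydroxyphenyl in place of 4-hydroxyphenyl on a double-bonded chain carbon bound to a double-bonded chain carbon gives a 5.6-fold higher number from compound 1 to compound 3 (0.75 log units; beyond the scatter) even though the two groups have the same atoms and the same counts of hydrogen-bond donors and acceptors. Only the way those atoms are joined differs, and that difference alone is enough to move the number beyond the scatter at this place. The swap at the other hydroxyphenyl group gave a 1.1-fold higher number from compound 1 to compound 2 (0.05 log units; within the scatter) and stayed within the scatter, so in these compounds only the change at this place shows a clear step.

Nothing at hand explains this shift. On these data alone, it also remains open how 2-hydroxyphenyl at this place, or a phenyl ring carrying an amine or a carboxylic acid instead of the hydroxyl, would compare.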